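Methoxy to hydrogen: a repeated step in the series

A few compounds are considered here, and "the series" means these few. Any claim that something is new, unique, unknown or untested is made for them only; others in the source may bear on it.

Three compounds of the series have numbers in a functional assay on SK-MEL-28 cells (Homo sapiens) for inhibition, read by sulforhodamine B assay, with a stated time of 48 h; on this read-out lower numbers stand for stronger inhibition of growth and higher numbers for weaker inhibition of growth. Compound 1 `COc1ccc(-c2cc(/C=C/C(=O)c3ccc(N)cc3)[nH]n2)cc1` gives 4010 nM. Compound 2 `COc1ccc(-c2cc(/C=C/C(=O)c3ccc(N)cc3)[nH]n2)cc1OC` gives 5660 nM. Compound 3 `COc1cc(C(=O)/C=C/c2cc(-c3cc(OC)c(OC)c(OC)c3)n[nH]2)cc(OC)c1OC` gives 3330 nM, the lowest of the three, but its distances to compound 1 and to compound 2 both lie within the scatter, so no ranking among the three is drawn. Compound 4 `COc1ccc(-c2cc(/C=C/C(=O)c3cc(OC)c(OC)c(OC)c3)[nH]n2)cc1OC` has not yet been measured in this assay.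

Compound 2 and compound 1 differ by hydrogen in place of methoxy on an aromatic carbon, and that step came out as a 1.4-fold lower number from compound 2 to compound 1 (0.15 log units; within the scatter), within the scatter. Compound 3 and compound 4 differ by hydrogen in place of methoxy on an aromatic carbon. The surroundings are not identical: in compound 3 the carbon that loses the methoxy is ortho to a methoxy group, meta to a large group and also meta to a methoxy group, whereas in compound 2 it is ortho to a methoxy group and meta to a large group only. The two changes are therefore the same kind of change, not the same change. The difference between the core of compound 3 and the core of compound 2 is not broken down here.

In this assay compound 4 is expected near 3000 nM, with a plausible span from 1500 nM to 6500 nM. Among the measured compounds shown here, the expected step of a 1.1-fold lower number from compound 3 to compound 4 (0.05 log units; within the scatter) is taken as small because the earlier step of a 1.4-fold lower number from compound 2 to compound 1 (0.15 log units; within the scatter) stayed within the scatter, and the one example gives no ground for more.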

Compound 4, concentration for total growth inhibition: 4410 nM
Compound 4: the middle estimate sits 1.5-fold (0.17 log units) below what was measured, and the stated range covers the measured number.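

In this assay, hydrogen in place of methoxy on an aromatic carbon gives a 1.3-fold higher number from compound 3 to compound 4 (0.12 log units; within the scatter). Set side by side, the two examples of this change show no difference that exceeds the usual variation between repeated measurements: the same change on two cores in this assay, a 1.4-fold lower number (0.15 log units; within the scatter) from compound 2 to compound 1 and a 1.3-fold higher number (0.12 log units; within the scatter) from compound 3 to compound 4, 1.9-fold (0.27 log units) apart, within the scatter of two such steps On these two cores, then, the change can be carried across with no measurable shift in either case, and the opposite directions of the two steps carry no weight, but this does not show that the change is without effect on other cores, at other places on the ring, or in other surroundings, and the carbon in compound 3 is also meta to a methoxy group, unlike the one in compound 2.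

The compounds shown leave open whether anything other than hydrogen at this carbon, such as a hydroxyl group, a fluorine atom or a longer chain like ethoxy, would move the number beyond the scatter. They also leave open whether a carboxylic acid or a dimethylamino group on the ring of the carbonyl side would give a step large enough to read.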